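Swapping an Amidoxime-Bearing Ring for a Single Chlorine

A few compounds are considered here, and "the series" means these few. Any claim that something is new, unique, unknown or untested is made for them only; others in the source may bear on it.

Compound 1 `CC1(c2ccc(-c3cccc(/C(N)=N\O)c3)cc2)CC(S(=O)(=O)c2ccc(F)cc2)=C(c2ccc(/C(N)=N\O)cc2)O1`: 19000 nM
Compound 2 `CC1(Cc2ccccc2)CC(S(=O)(=O)c2c(F)cccc2F)=C(c2ccc(/C(N)=N\O)cc2)O1`: 91400 nM

In an ADME assay on HepG2 cells (Homo sapiens) for cytotoxicity, read by MTT assay, with a stated time of 72 h (a higher number here means that more compound is tolerated, a lower number that less compound is tolerated), compound 1 gives 19000 nM, the lower of the two numbers, so less of it is tolerated than of compound 2, which in this assay gives 91400 nM. Compound 3 `CC1(c2ccc(Cl)cc2)CC(S(=O)(=O)c2ccc(F)cc2)=C(c2ccc(/C(N)=N\O)cc2)O1` has not been measured. It differs from compound 1 at one point: one chlorine atom in place of a group of 10 heavy atoms (7 carbon, 2 nitrogen, 1 oxygen; one six-membered aromatic ring of carbon only), on an aromatic carbon. Going by the values given here, no measured pair shares this change, so its effect cannot be read from the data. A modest rise in tolerated concentration is expected, a 1.8-fold higher number from compound 1 to compound 3 (0.27 log units; within the scatter), possibly still within the scatter. Compound 3 is estimated at 35000 nM, within a range from 12000 nM to 100000 nM.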

Compound 3, half-maximal cytotoxic concentration: 61400 nM
Beside the measured number, compound 3's estimate is 1.8-fold (0.24 log units) below it; low and high end bracket the measured number.
By their numbers in this assay, from the lowest: compound 1; then compounds 3 and 2 (each within the scatter of the next).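

Compound 1 and compound 2 differ in more than one place, so they could not isolate any single change. In this assay, one chlorine atom on this aromatic carbon, in place of the amidoxime-bearing ring, gives a 3.2-fold higher number from compound 1 to compound 3 (0.51 log units; beyond the scatter) and so shows that this position alone can shift how much compound is tolerated. Nothing available explains the shift.

On these data alone, what a fluorine, a methyl or an amine would do at this position stays open. So does whether the same swap would have a similar effect on a different core.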